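This account rests on a few compounds, and the source may have more. Where it says the series, first, only, none or still open, it means among the compounds named here.

Compound 3 `Cc1cc(NC(=O)Nc2ccc(N(C)C)cc2)c2ccccc2n1` carries a dimethylamino group on an aromatic carbon; compound 1 `Cc1cc(NC(=O)Nc2ccccc2OC(F)(F)F)c2ccccc2n1` and compound 2 `CCc1ccc(NC(=O)Nc2cc(C)nc3ccccc23)cc1` are the other two measured members of the series, and compound 4 `Cc1cc(NC(=O)Nc2ccc(SC(F)(F)F)cc2)c2ccccc2n1` is the one still to be measured. In an ADME assay on BJ cells (Homo sapiens) for cytotoxicity, with a stated time of 72 h (on this read-out higher numbers stand for an effect only at larger amounts of compound and lower numbers for an effect already at smaller amounts), compound 1 gives > 25000 nM, which is a limit of the assay and not a number. In this assay compound 2 gives > 25000 nM, likewise a limit. In this assay compound 3 gives > 25000 nM, again a limit. Compound 3 thus stands where every other measured compound stands, at the limit of > 25000 nM in this assay, at which 3 of the 3 values shown sit. Going by the values given here, the one single-point step among the measured compounds, a step that the two limits leave unreadable from compound 2 to compound 3, runs between two such limits and its size cannot be read.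

The change from compound 3 to compound 4 is (trifluoromethyl)sulfanyl in place of dimethylamino on an aromatic carbon. Among the compounds with values here, no measured step bears on it in a readable way, since every value shown is a limit. Nothing in the numbers points to a step of any size in this assay in either direction. The expectation for compound 4 is therefore that it too will return at the limit, estimated at 40000 nM with a range from 12000 nM to 150000 nM. The step this estimate implies is expected to be a step that the limit leaves unreadable from compound 3 to compound 4, within the scatter.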

Compound 4, half-maximal effective concentration: > 25000 nM
Compound 4 ended at the assay's limit; the forecaster's own chance of this, stated with the estimate: 85%; the middle value is on the limit's open side.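

No new step can be read in this assay: the steps from compound 3 to compound 4 and from compound 2 to compound 4 each run between two limits, and neither size is readable. All measured values coincide: the limit of > 25000 nM in this assay, at which 4 of the 4 values shown sit.

The compounds shown leave open at what concentration any of the four would show an effect, and whether changing the group on the shared core would shift it.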